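The source may report more compounds than this note shows. Statements on the series, on what has been measured and on what is new or still open speak of the compounds shown alone.

In an ADME assay on BaF3 cells (Mus musculus) for cytotoxicity, read by MTT assay, with a stated time of 48 h (a higher number here means a weaker inhibitor of growth, a lower number a stronger inhibitor of growth), compound 3 (`Nc1ncnc2c1c(-c1cc(C3CC3)on1)nn2C1CCCCC1`) gives > 10000 nM, which is a limit of the assay and not a number. Compound 1 (`CC(C)n1nc(-c2cc(C3CCCCC3)on2)c2c(N)ncnc21`) gives > 10000 nM, also a limit. Compound 2 (`CC(C)n1nc(-c2cc(C(C)(C)C)on2)c2c(N)ncnc21`) gives > 10000 nM, again a limit. Every measurement so far therefore sits at the same ceiling: the limit of > 10000 nM in this assay, at which 3 of the 3 values shown sit.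

Compound 4 (`CCCCCCCn1nc(-c2cc(C3CC3)on2)c2c(N)ncnc21`) carries one change, heptyl in place of cyclohexyl on an aromatic nitrogen. Going by the values given here, the only measured step is a step that the two limits leave unreadable from compound 1 to compound 2. It has no readable size, and it concerns a group on an aromatic carbon, so it gives no size to carry over to this change.

Among the compounds with values here, with no measured step pointing either way, the expectation rests on compound 3 at > 10000 nM, a limit. No shift beyond the scatter is expected in this assay, and another limit is the likeliest report. The expected step is a number no higher from compound 3 to compound 4 (the limit leaves the size open). Compound 4 is estimated at 10000 nM, with an expected range of 4000 nM to 25000 nM.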

Compound 4, concentration for 50% growth inhibition: > 10000 nM
Compound 4: only a limit was reported; the forecaster's own chance of this, stated with the estimate: 75%; the middle value lies on the limit itself.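

Compound 3 and compound 4 both sit at a limit of the assay, so the step between them, heptyl in place of cyclohexyl, cannot be read. The compounds shown share one ceiling: the limit of > 10000 nM in this assay, at which 4 of the 4 values shown sit. They leave open whether any of these changes alters growth inhibition in this assay.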